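The compounds below may be only part of what the source reports. "The series", "measured", "known", "first", "only" and "open" are said of these compounds alone.

Compound 1 `O=C(Nc1ccc(Cl)c(-c2nnc3c(Cl)cccn23)c1)c1ccccc1` stands only at a limit in a functional assay on T47D cells (Homo sapiens) for antiproliferative activity, read by MTT assay, with a stated time of 72 h; on this read-out lower numbers stand for stronger inhibition and higher numbers for weaker inhibition: compound 1 gives > 100000 nM, a limit rather than a number. Compound 2 `O=C(Nc1ccc(Cl)c(-c2nnc3c(Cl)cccn23)c1)c1cccc(Cl)c1` gives 30200 nM in this assay. The step is an at least 3.3-fold lower number from compound 1 to compound 2 (0.51 log units; beyond the scatter). Compound 3 `O=C(Nc1ccc(Cl)c(-c2nnc3c(Cl)cccn23)c1)c1ccc(C(F)(F)F)cc1Cl` also reports only a limit in this assay, > 100000 nM. Compound 4 `O=C(Nc1ccc(Cl)c(-c2nnc3c(Cl)cccn23)c1)c1ccc(Cl)cc1Cl` is unmeasured; it differs from compound 1 by 2,4-dichlorophenyl in place of phenyl on a carbonyl carbon. The step from compound 1 to compound 2 bears on it, a single chloro entering the phenyl on the carbonyl carbon. Compound 3, with two substituents on that phenyl, sits at the limit of > 100000 nM in this assay, at which 2 of the 3 values shown sit. A modest downward step is therefore expected from compound 1 to compound 4, an at least 1.6-fold lower number from compound 1 to compound 4 (0.22 log units; that floor lies within the scatter), with a real chance of another limit. Compound 4 is estimated at 60000 nM, range 20000 nM to 150000 nM.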

Compound 4, half-maximal inhibitory concentration: > 100000 nM
Compound 4: only a limit was reported (the forecaster's own chance of this, stated with the estimate: 50%); middle value at least 1.6-fold (0.22 log units) away from the limit.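

Replacing 3-chlorophenyl with 2,4-dichlorophenyl on the carbonyl carbon gives an at least 3.3-fold higher number from compound 2 to compound 4 (0.51 log units; beyond the scatter), so the gain seen with a single chloro does not carry over to this dichloro pattern. The steps to compound 4 from compound 1 and from compound 3 join two limits and cannot be read. Compound 4 is a limit and joins the largest group in this assay: the limit of > 100000 nM in this assay, at which 3 of the 4 values shown sit.

Open, going by these compounds, is whether an amine or a carboxylic acid in place of chloro on the phenyl would keep a measurable number. Compound 1, compound 3 and compound 4 also remain unranked against one another.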